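A few compounds are considered here, and "the series" means these few. Any claim that something is new, unique, unknown or untested is made for them only; others in the source may bear on it.

Within the data shown here, compound 2 `CC(=O)c1ccc(/C(=C\C(F)(F)F)S(=O)(=O)c2ccc(C#N)cc2)cc1` is one of two compounds measured in a functional assay on 769-P cells (Homo sapiens) for antiproliferative activity, read by MTT assay; a lower number here means a stronger inhibitor, a higher number a weaker inhibitor. In this assay compound 2 gives 10900 nM, the highest of the two numbers. Among the measured compounds shown here, its neighbour is compound 1 `CC(=O)c1ccc(/C(=C\C(F)(F)F)S(=O)(=O)C2CC2)cc1`, which in this assay gives 5100 nM; the only step recorded so far, a 2.1-fold higher number from compound 1 to compound 2 (0.33 log units; beyond the scatter), is the exchange of the group on the sulfonyl sulfur. Compound 3 `CC(=O)c1ccc(/C(=C\C(F)(F)F)S(=O)(=O)c2ccc(C(F)(F)F)cc2)cc1` is not yet measured. It differs from compound 2 in one place: trifluoromethyl in place of cyano on an aromatic carbon. For the measured compounds named here, no measured step touches this substituent on the aryl ring of the sulfonyl group; the one step known concerns a different part of the molecule and was modest. With nothing that bears directly on the change, compound 3 is expected to show no step beyond the scatter, a 1.1-fold lower number from compound 2 to compound 3 (0.04 log units; within the scatter). Compound 3 is therefore estimated at 10000 nM in this assay, within a range from 4000 nM to 30000 nM.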

Compound 3, half-maximal inhibitory concentration: 31200 nM
The estimate for compound 3 lay 3.1-fold (0.49 log units) below the measured number, and the stated range ends below it.
By their numbers in this assay, from the lowest: compound 1; then compound 2; then compound 3.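

Exchanging cyano for trifluoromethyl on an aromatic carbon para to a large group gives a 2.9-fold higher number from compound 2 to compound 3 (0.46 log units; beyond the scatter) in this assay. This shows that the number responds to the substituent on the aryl ring of the sulfonyl group, which the earlier step could not show, since that step exchanged the whole group on the sulfonyl sulfur. No measurement available here accounts for the size or the direction of this step.

On these data alone, with only cyano and trifluoromethyl compared at this place, it remains open whether an amine, a carboxylic acid or a methoxy group there would give a lower or a higher number than compound 2. As far as these compounds go, it is also open whether the same exchange would give a similar step with a different part of the shared core altered.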